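The source may hold more compounds than are shown below. What is called first, only, known or untested is meant among the compounds shown, and "the series" means these compounds.

Going by the values given here, compound 2 `Cn1ncnc1-c1ccccc1NCC1=NCCN1` stands at the top of the two compounds measured so far in a functional assay with Alpha-1B adrenergic receptor (Homo sapiens) as the target, read by calcium flux; a higher number here means a larger maximal response, a lower number a smaller maximal response: compound 2 gives 93%, while compound 1 `Cn1cc(-c2ccccc2NCC2=NCCN2)cn1` gives 0%. Among the compounds with values here, the single measured step, a number 93 percentage points higher from compound 1 to compound 2 (beyond the scatter), is the only guide available. Compound 3 `Cn1ccc(-c2ccccc2NCC2=NCCN2)n1` arises from compound 2 by one change: 1-methyl-1H-pyrazol-3-yl in place of 1-methyl-1H-1,2,4-triazol-5-yl on an aromatic carbon. That earlier step bears on this one only loosely. It showed that exchanging 1-methyl-1H-pyrazol-4-yl for 1-methyl-1H-1,2,4-triazol-5-yl can lift the maximal response from nothing to near the full reference. Here the triazole leaves again and a pyrazole returns, though not the same group as in compound 1, so the outcome need not repeat exactly. A fall is expected, a number 53 percentage points lower from compound 2 to compound 3 (beyond the scatter), with wide uncertainty. Compound 3 is therefore estimated at 40% in this assay, within a range from 0% to 90%.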

Compound 3, largest response reached (reported as maximal response), in percent of the reference or control that the assay uses: 33%
Compound 3: middle estimate off by 7 percentage points, on the high side; the measured number falls inside the stated range.
By their numbers in this assay, from the lowest: compound 1; then compound 3; then compound 2.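

In this assay, this place on the aromatic carbon now holds three different five-membered rings, and the response differs clearly for each. Replacing the triazole with 1-methyl-1H-pyrazol-3-yl gives a number 60 percentage points lower from compound 2 to compound 3 (beyond the scatter) and so removes much of the response, but not all of it. The two pyrazoles differ in name only by 3-yl against 4-yl, and that change alone gives a number 33 percentage points higher from compound 1 to compound 3 (beyond the scatter) and separates a compound with no measurable response from one with a partial response, so knowing that the ring is a pyrazole does not settle the outcome. Still open, from the compounds shown here alone, is what an amine or a longer chain on the pyrazole would do to the maximal response. No available evidence explains why these three rings give such different responses.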